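A few compounds are considered here, and "the series" means these few. Any claim that something is new, unique, unknown or untested is made for them only; others in the source may bear on it.

Measured so far in an ADME assay on Vero cells (Chlorocebus sabaeus) for cytotoxicity, read by MTT assay, with a stated time of 72 h; on this read-out lower numbers stand for an effect already at smaller amounts and higher numbers for an effect only at larger amounts of compound:
- compound 1 `Cc1cccc(C(=O)Nc2nc(-c3ccccn3)cs2)c1` gives 4100 nM
- compound 2 `O=C(Nc1nc(-c2ccccn2)cs1)c1ccccc1O` gives "not determined" (no result reported)
- compound 3 `O=C(Nc1nc(-c2ccccn2)cs1)c1cccc(Cl)c1` gives 7000 nM

Compound 3 stands level with compound 1 within the scatter. Compound 4 `O=C(Nc1nc(-c2ccccn2)cs1)c1ccccn1` is next, with this change: pyridin-2-yl in place of 3-chlorophenyl on a carbonyl carbon and thus pyridin-2-yl in place of 3-chlorophenyl on a carbonyl carbon. Among the measured compounds shown here, the only measured step is a 1.7-fold higher number from compound 1 to compound 3 (0.23 log units; within the scatter) and swaps chloro for methyl on an aromatic carbon, so it bears only loosely on this replacement. For the measured compounds named here, no measured step covers the replacement itself. In this assay no step beyond the scatter is therefore expected. The expected change is a 1.4-fold higher number from compound 3 to compound 4 (0.15 log units; within the scatter) and remains a rough estimate. For compound 4 the estimated value is 10000 nM with an expected range from 3000 nM to 35000 nM as its limits.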

Compound 4, half-maximal effective concentration: 5400 nM
The estimate for compound 4 lay 1.9-fold (0.27 log units) above the measured number, within the range that was stated.
By their numbers in this assay, from the lowest: compounds 1, 4 and 3 (each within the scatter of the next).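

In this assay the replacement on the carbonyl carbon gives a 1.3-fold lower number from compound 3 to compound 4 (0.11 log units; within the scatter) and, with pyridin-2-yl in place of 3-methylphenyl, a 1.3-fold higher number from compound 1 to compound 4 (0.12 log units; within the scatter). The earlier step covered only chloro for methyl, whereas these steps show that exchanging the whole ring for one with a hetero atom also stays within the scatter. Nothing measured here offers an explanation for this.

Steps involving compound 2 cannot be read, as it has no reported result. Open, from the compounds shown here alone, is whether an amine, a carboxylic acid or a saturated ring at this place would give a step beyond the scatter.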